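The source may hold more compounds than are shown below. What is called first, only, known or untested is meant among the compounds shown, and "the series" means these compounds.

Measured in a functional assay on the whole organism (blood, strain Charles Foster/Wistar albino) with Rattus norvegicus as the target, with a stated time of 30 min, at a dose of 100 mg/kg by the oral route; a higher number here means more inhibition at the dose given (going by the name of the read-out), a lower number less inhibition:

compound 1, `CCN(CC)CCCOc1cc(OC)ccc1-c1cc(-c2ccccc2)no1`: 14.3%
compound 2, `CCCCN(C)CCCOc1cc(OC)ccc1-c1cc(-c2ccccc2)no1`: 15%
compound 3, `COc1ccc(-c2cc(-c3ccccc3)no2)c(OCC(=O)O)c1`: 11.7%

The three compounds share one core and differ only in the chain attached through the oxygen on the aromatic ring. Compound 1 sits within the usual scatter of both neighbours: the change to compound 2 gave a number 0.7 percentage points higher from compound 1 to compound 2 (within the scatter), and the change to compound 3 gave a number 2.6 percentage points lower from compound 1 to compound 3 (within the scatter). The step from compound 2 to compound 3 was a number 3.3 percentage points lower from compound 2 to compound 3 (within the scatter). So far, then, swapping the group at the end of the chain, or replacing the whole chain with a carboxy, has not moved the read-out beyond what repeated measurements would show anyway.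

Compound 4, `CCN(CC)CC(O)COc1cc(OC)ccc1-c1cc(-c2ccccc2)no1`, has not yet been measured. It differs from compound 1 by hydroxy in place of hydrogen on a saturated chain carbon bound to two saturated chain carbons. Among the measured compounds shown here, none of the measured steps touches this place on the chain, so nothing seen so far speaks directly to it; what the three compounds do show is that changes along this chain have stayed within the scatter. On that basis compound 4 is expected to give a value close to compound 1, with the step of a number 0.3 percentage points lower from compound 1 to compound 4 (within the scatter) expected to lie within the scatter. The estimate for compound 4 is 14%, expected between 5% and 24%.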

Compound 4, a percentage reported as inhibition, in the whole organism at one dose (the size of the read-out at that dose, not a potency): 13.8%
The estimate for compound 4 lay 0.2 percentage points above the measured number; measured number inside the range.
By their numbers in this assay, from the lowest: compounds 3, 4, 1 and 2 (each within the scatter of the next).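

In this assay, among the compounds shown here, placing a hydroxy on a saturated chain carbon bound to two saturated chain carbons, a place no earlier step had touched, gave a number 0.5 percentage points lower from compound 1 to compound 4 (within the scatter). So, at this dose, the read-out does not separate 3-(diethylamino)-2-hydroxypropyl from 3-(diethylamino)propyl, and the hydroxy compound also stays close to the other two compounds, with a number 2.1 percentage points higher from compound 3 to compound 4 (within the scatter) and a number 1.2 percentage points lower from compound 2 to compound 4 (within the scatter). No separate measurement is available to shed light on this result.

The compounds shown leave open whether a different group at this chain carbon, such as methoxy, fluorine or a carbonyl, would also stay within the scatter, and whether the hydroxy would behave the same way alongside the butyl(methyl)amino group of compound 2. They also leave open whether a longer chain or a ring amine such as piperidine or morpholine at the chain end would shift the read-out, and whether any of these small differences would hold at another dose or time.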